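Compound 4 Against a Cytotoxicity Limit

The source may report more compounds than this note shows. Statements on the series, on what has been measured and on what is new or still open speak of the compounds shown alone.

Measured so far in an ADME assay on NIH3T3 cells (Mus musculus) for cytotoxicity, with a stated time of 72 h; a higher number here means a weaker inhibitor, a lower number a stronger inhibitor
- compound 1 `OC[C@H]1O[C@@H](n2cnc3c(NCc4ccccc4Br)ncnc32)[C@H](O)[C@@H]1O` gives > 166000 nM (a limit)
- compound 2 `OC[C@H]1O[C@@H](n2cnc3c(NCc4ccc(Cl)cc4Cl)ncnc32)[C@H](O)[C@@H]1O` gives "not determined" (no result reported)
- compound 3 `COc1ccc(CNc2ncnc3c2ncn3[C@@H]2O[C@H](CO)[C@@H](O)[C@H]2O)c(OC)c1` gives "not determined" (no result reported)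

Compound 3 has no single number to its name, and its entry reads ("not determined" (no result reported)). Compound 2 offers no firmer footing, with the entry ("not determined" (no result reported)). The only figure in the set belongs to compound 1, whose entry (> 166000 nM) is a limit of the assay and not a number.

Attention now turns to compound 4 `OC[C@H]1O[C@@H](n2cnc3c(NCc4ccc(F)cc4Cl)ncnc32)[C@H](O)[C@@H]1O`, which has yet to be measured. The change 2-chloro-4-fluorophenyl in place of 2,4-dimethoxyphenyl on a saturated chain carbon bound to a nitrogen on an aromatic ring puts 2-chloro-4-fluorophenyl in place of 2,4-dimethoxyphenyl on a saturated chain carbon bound to a nitrogen on an aromatic ring. Among the compounds with values here, no measured pair shows what such a swap does in this assay, so no step beyond the usual scatter is expected from the one reading available, that of compound 1 (> 166000 nM). A report of only a limit is the likeliest outcome. For compound 4 the estimated value is 170000 nM, with an expected range from 60000 nM to 300000 nM.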

Compound 4, half-maximal inhibitory concentration: > 166000 nM
Compound 4: only a limit was reported; the forecaster's own chance of this, stated with the estimate: 70%; the middle value is on the limit's open side.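

Compound 1 and compound 4 both end at a limit of the assay and not at a number, so no step between them can be read: the limit of > 166000 nM in this assay, at which 2 of the 4 values shown sit.

The compounds shown leave open where the half-maximal inhibitory concentration of either compound lies in this assay.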